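Stilbene series: methylsulfanyl for propoxy on compound 3

The source may report more compounds than this note shows. Statements on the series, on what has been measured and on what is new or still open speak of the compounds shown alone.

Measured compounds:
compound 1 `COc1cc(/C=C/c2ccc(C(C)(C)C)cc2)cc(OC)c1OC`; in a functional assay on HT-29 cells (Homo sapiens) for cytotoxicity (a lower number here means that less compound is needed, a higher number that more compound is needed for the effect), compound 1 gives > 25 uM, a limit of the assay.
compound 2 `CCCOc1ccc(/C=C\c2cc(OC)c(OC)c(OC)c2)cc1`; in this assay compound 2 gives 2.8 uM.
compound 3 `CCCOc1ccc(/C=C/c2cc(OC)c(OC)c(OC)c2)cc1`; in this assay compound 3 gives > 25 uM, a limit of the assay.

Compound 3 sits at the limit and returns no number. Compound 1 also sits at the limit. Only compound 2 gives a number; the step of an at least 8.9-fold higher number from compound 2 to compound 3 (0.95 log units; beyond the scatter) rests on (the fact that compounds 2 and 3 differ only in the configuration as drawn). The step that the two limits leave unreadable from compound 1 to compound 3 is unreadable due to the limit of > 25 uM in this assay, at which 2 of the 3 values shown sit.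

Compound 4 `COc1cc(/C=C/c2ccc(SC)cc2)cc(OC)c1OC` carries methylsulfanyl in place of propoxy on an aromatic carbon. Within the data shown here, no measured step reads this change directly; the only comparison of groups at this position is unreadable. The expectation is therefore no step beyond the scatter, a step that the limit leaves unreadable from compound 3 to compound 4, and compound 4 is estimated at 30 uM (range 8 uM to 100 uM), most likely again reported as a limit.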

Compound 4, concentration for half-maximal effect: 8.3 uM
Compound 4: middle estimate off by 3.6-fold (0.56 log units), on the high side; measured number inside the range.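

Among the compounds drawn E, only compound 4 returns a number in this assay, so the group at this position does change the read-out, which the earlier compounds could not show. Methylsulfanyl in place of propoxy gives an at least 3.0-fold lower number from compound 3 to compound 4 (0.47 log units; beyond the scatter), and methylsulfanyl in place of tert-butyl gives an at least 3.0-fold lower number from compound 1 to compound 4 (0.47 log units; beyond the scatter). Both steps start from limits, so only a minimum size can be read, and the step between tert-butyl and propoxy still cannot be read: the limit of > 25 uM in this assay, at which 2 of the 4 values shown sit.

Open, going by these compounds, is whether methylsulfanyl with the double bond drawn Z follows the step seen for propoxy. Also open, on these data alone, is how an ethylsulfanyl group or an amine at this position would read.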